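The compounds below may be only part of what the source reports. "The series", "measured", "known", "first", "only" and "open" are said of these compounds alone.

Working notes on the series. In an in vitro functional assay on 1321-N1 cells for agonist activity at Free fatty acid receptor 1 (Homo sapiens), read by fluorescence, spectrophotometry and calcium flux (on this read-out higher numbers stand for larger maximal responses and lower numbers for smaller maximal responses), compound 1 `O=C(O)CCc1ccc(C#Cc2cccnc2)cc1` gives 96% and compound 2 `Cc1ccccc1-c1cc(C#Cc2ccc(CCC(=O)O)cc2)ccn1` gives 92%. Compound 3 `COc1cc(C#Cc2ccc(CCC(=O)O)cc2)ccn1` gives 98% in this assay and so stands with the highest of the three numbers, although its gaps to compound 1 and to compound 2 both lie within the scatter. Among the measured compounds shown here, the only measured step, a number 6 percentage points higher from compound 2 to compound 3 (within the scatter), changes the same aromatic carbon that is altered next. Compound 4 `O=C(O)CCc1ccc(C#Cc2ccncc2)cc1` differs from compound 3 by hydrogen in place of methoxy on an aromatic carbon. That step to compound 3 stayed within the scatter, and all three measured values sit within the scatter of one another, so for compound 4 no change beyond the scatter in this assay is expected. The estimated step is a number 4 percentage points lower from compound 3 to compound 4 (within the scatter). Compound 4 is expected to reach 94%, within 82% to 105%.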

Compound 4, largest response reached (reported as efficacy), in percent of the reference or control that the assay uses: 100%
The estimate for compound 4 lay 6 percentage points below the measured number, within the range that was stated.
By their numbers in this assay, from the lowest: compounds 2, 1, 3 and 4 (each within the scatter of the next).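

At the aromatic carbon next to the ring nitrogen, hydrogen now joins methoxy and 2-methylphenyl with no resolved change in this assay, giving a number 2 percentage points higher from compound 3 to compound 4 (within the scatter) and a number 8 percentage points higher from compound 2 to compound 4 (within the scatter). Pyridin-4-yl in place of pyridin-3-yl is also unresolved, giving a number 4 percentage points higher from compound 1 to compound 4 (within the scatter). No evidence bears on these results. As far as these compounds go, whether an amine or a fluorine atom on this carbon would move the maximal response beyond the scatter remains open.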